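The source may hold more compounds than are shown below. What is called first, only, known or untested is meant among the compounds shown, and "the series" means these compounds.

Compound 1 `COc1ncc(-c2ccc3nccc(-c4ccc(C)cc4)c3c2)cc1NS(=O)(=O)c1ccc(F)cc1F` gives 2540 nM in a functional assay on HCT-116 cells (Homo sapiens) for cytotoxicity, read by MTT assay, with a stated time of 72 h (a lower number here means a stronger inhibitor, a higher number a weaker inhibitor), the highest of the three numbers in hand. Compound 2 `CCN(CC)Cc1ccc(-c2ccnc3ccc(-c4cnc(OC)c(NS(=O)(=O)c5ccc(F)cc5F)c4)cc23)cc1` gives 5 nM and compound 3 `COc1ncc(-c2ccc3nccc(-c4ccc(CN5CCN(C)CC5)cc4)c3c2)cc1NS(=O)(=O)c1ccc(F)cc1F` gives 43.9 nM; the corresponding steps are a 510-fold lower number from compound 1 to compound 2 (2.71 log units; beyond the scatter) and a 58-fold lower number from compound 1 to compound 3 (1.76 log units; beyond the scatter), with an 8.8-fold higher number from compound 2 to compound 3 (0.94 log units; beyond the scatter) between the two substituted analogues. Compound 4 `COc1ncc(-c2ccc3nccc(-c4ccc(CN5CCN(C(C)C)CC5)cc4)c3c2)cc1NS(=O)(=O)c1ccc(F)cc1F` differs from compound 1 as follows: 4-isopropylpiperazin-1-yl in place of hydrogen on a saturated chain carbon bound to an aromatic carbon. The two steps from compound 1 bear directly on this change, both large and both downward, the 4-methylpiperazin-1-yl case being the closer match. A large downward step is therefore expected, estimated as a 73-fold lower number from compound 1 to compound 4 (1.86 log units; beyond the scatter). For compound 4 the value in this assay is expected to be 35 nM, within 8 nM to 150 nM.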

Compound 4, half-maximal inhibitory concentration: 24.7 nM
For compound 4 the middle estimate is 1.4-fold (0.15 log units) above the measured one; low and high end bracket the measured number.
By their numbers in this assay, from the lowest: compound 2; then compounds 4 and 3 (each within the scatter of the next); then compound 1.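

In this assay, a third amine group on this saturated chain carbon bound to an aromatic carbon gives a 100-fold lower number from compound 1 to compound 4 (2.01 log units; beyond the scatter), so the large downward step holds for all three amine groups shown. On the amine nitrogen in a ring, isopropyl in place of methyl gives a 1.8-fold lower number from compound 3 to compound 4 (0.25 log units; within the scatter), which does not separate these two substituents. Changing from diethylamino to 4-isopropylpiperazin-1-yl gives a 4.9-fold higher number from compound 2 to compound 4 (0.69 log units; beyond the scatter), and no measurement at hand accounts for that difference.

From the compounds shown here alone, whether morpholin-4-yl, a primary amine or a carboxylic acid at this carbon would give similarly low numbers stays open. So does the effect of a longer chain carrying the amine.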